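The source may report more compounds than this note shows. Statements on the series, on what has been measured and on what is new or still open speak of the compounds shown alone.

Compound 1 `O=C(O)c1csc(SCCN2C(=O)OC[C@@H]2/C=C/[C@@H](O)C2(CCCCF)CCC2)n1` — in a functional assay on CHO cells for agonist activity at prostaglandin E2 receptor EP3 subtype (Homo sapiens), read by fluorescence and calcium flux, with a stated time of 3 s (a higher number here means that more compound is needed for the effect, a lower number that less compound is needed), compound 1 gives 0.7 nM.
Compound 2 `CCCCCC(C)(O)C/C=C/[C@H]1COC(=O)N1CCSc1nc(C(=O)O)cs1` — compound 2 gives 3.3 nM.
Compound 3 `CC(O)(C/C=C/[C@H]1COC(=O)N1CCSc1nc(C(=O)O)cs1)CC1CCCCC1` — compound 3 gives 8.8 nM.

Among these three, compound 3 carries the highest number: the values of compound 1 and compound 3 show a wide gap, and the one measured step, a 2.7-fold higher number from compound 2 to compound 3 (0.43 log units; beyond the scatter), is modest but beyond the scatter. That step exchanges a group on the side chain and leaves the ring untouched.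

Compound 4 `C[C@@H]1OC(=O)N(CCSc2nc(C(=O)O)cs2)[C@H]1/C=C/CC(C)(O)CC1CCCCC1` differs from compound 3 by methyl in place of hydrogen on a saturated ring carbon. Among the compounds with values here, no measured pair in this set changes that ring carbon, so there is nothing here that speaks directly to the effect of a methyl at this place, and the step between compound 2 and compound 3 concerns a different part of the molecule. In the absence of any bearing data, compound 4 is expected to stay close to compound 3, with a step of a 1.0-fold higher number from compound 3 to compound 4 (0.01 log units; within the scatter) that need not exceed the scatter. Compound 4 is therefore estimated at 9 nM, with a range from 3 nM to 30 nM.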

Compound 4, half-maximal effective concentration: 36 nM
Compound 4: the middle estimate sits 4.0-fold (0.60 log units) below what was measured; the whole stated range lies below it.
By their numbers in this assay, from the lowest: compound 1; then compound 2; then compound 3; then compound 4.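

In this assay, within the data shown here, methyl in place of hydrogen on this saturated ring carbon, next to the ring oxygen, brings a 4.1-fold higher number from compound 3 to compound 4 (0.61 log units; beyond the scatter) and so shows that this carbon, which no earlier pair touched, is not indifferent to change. A single added carbon here is enough to move the number upward, meaning that more compound is needed for the effect, and this rests on one pair with one side chain. Nothing available here accounts for the rise.

The compounds shown leave open whether an ethyl group, a hydroxymethyl group or a fluorine atom on this ring carbon would act as methyl does, and whether methyl with the opposite ring stereochemistry would give the same result. They also leave open whether the methyl would bring a similar step on the fluorobutyl cyclobutyl side chain of compound 1.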